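The source may hold more compounds than are shown below. What is called first, only, known or untested is meant among the compounds shown, and "the series" means these compounds.

Compound 2 `c1ccc(-c2cn[nH]c2)c(NCC2=NCCN2)c1` stands highest of the three numbers in a functional assay with Alpha-1D adrenergic receptor (Homo sapiens) as the target, read by calcium flux (on this read-out higher numbers stand for larger maximal responses and lower numbers for smaller maximal responses), where compound 2 gives 62%; compound 1 `Cc1ccc(-c2ccccc2NCC2=NCCN2)n1C` gives 0% and compound 3 `CCn1cc(-c2ccccc2NCC2=NCCN2)cn1` gives 0%. Compound 4 `Cn1ccnc1-c1ccccc1NCC1=NCCN1` is compound 2 with the change (1-methyl-1H-imidazol-2-yl in place of 1H-pyrazol-4-yl on an aromatic carbon). Among the measured compounds shown here, no measured step matches this change exactly. The step of a number 62 percentage points lower from compound 2 to compound 3 (beyond the scatter) shows that an ethyl in place of the hydrogen on an aromatic nitrogen removed the response. Compound 1, whose five-membered ring also carries no hydrogen-bond donor, gives 0%. The entering 1-methyl-1H-imidazol-2-yl brings 0 hydrogen-bond donors, in line with both of those. A large downward step is therefore expected for compound 4, namely a number 52 percentage points lower from compound 2 to compound 4 (beyond the scatter). Compound 4 is estimated at 10%, within a range from 0% to 45%.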

Compound 4, largest response reached (reported as maximal response), in percent of the reference or control that the assay uses: 92%
For compound 4 the middle estimate is 82 percentage points below the measured one; measured number above the stated range.
By their numbers in this assay, from the lowest: compounds 1 and 3 (each within the scatter of the next); then compound 2; then compound 4.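

In this assay, the change on this aromatic carbon gives a number 30 percentage points higher from compound 2 to compound 4 (beyond the scatter), so 1-methyl-1H-imidazol-2-yl, with 0 hydrogen-bond donors, supports a larger maximal response than 1H-pyrazol-4-yl. A hydrogen-bond donor on the five-membered ring is therefore not required for a response at this position, and its absence alone does not account for the values of compound 1 and compound 3. Nothing measured here bears on the reason for this rise.

The compounds shown leave open whether the methyl group or the placement of the ring nitrogens carries the gain. From the compounds shown here alone, it also remains open how an unsubstituted 1H-imidazol-2-yl or a thiazol-2-yl would fare here.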